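This account rests on a few compounds, and the source may have more. Where it says the series, first, only, none or still open, it means among the compounds named here.

Compound 1 `CC1=C(CC(=O)NCCN(C)C)c2cc(F)ccc2/C1=C\c1nc2ccccc2s1`: 4880 nM
Compound 2 `CC1=C(CC(=O)NCCN(C)C)c2cc(F)ccc2/C1=C\c1ccncc1`: 28900 nM
Compound 3 `CC1=C(CC(=O)NCCN(C)C)c2cc(F)ccc2/C1=C\c1ccc(S(C)(=O)=O)cc1`: > 50000 nM, a limit of the assay and not a number

In a functional assay on PC-3 cells (Homo sapiens) for inhibition, read by CellTiter-Glo, with a stated time of 72 h (a higher number here means that more compound is tolerated, a lower number that less compound is tolerated), compound 2 carries the higher of the two true numbers, 28900 nM. Among the compounds with values here, the gap to the only other true number is a 5.9-fold higher number from compound 1 to compound 2 (0.77 log units; beyond the scatter). Compound 3 gives no number, only (the limit of > 50000 nM in this assay, at which 1 of the 3 values shown sits).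

Compound 4 `CC1=C(CC(=O)NCCN2CCCC2)c2cc(F)ccc2/C1=C\c1ccncc1` keeps everything in compound 2 except the amine at the end of the side chain: pyrrolidin-1-yl in place of dimethylamino on a saturated chain carbon, two bonds along the chain from an amide-type nitrogen. In words, pyrrolidin-1-yl stands in place of dimethylamino on a saturated chain carbon, two bonds along the chain from an amide-type nitrogen.

The measured steps offer only indirect help. The modest 5.9-fold higher number from compound 1 to compound 2 (0.77 log units; beyond the scatter) and the large at least 10-fold higher number from compound 1 to compound 3 (1.01 log units; beyond the scatter) both swap the group on the double-bonded chain carbon, while all three measured compounds share the dimethylamino end. Within the data shown here, they show that the numbers can move when the other end of the molecule changes, but no measured step touches this amine. Among the measured compounds shown here, with no direct precedent, the expected change is small, and the estimated result is a 1.3-fold lower number from compound 2 to compound 4 (0.12 log units; within the scatter), probably not beyond the scatter. For compound 4 the estimated value is 22000 nM, with an expected range from 9000 nM to 50000 nM.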

Compound 4, half-maximal cytotoxic concentration: 10200 nM
Estimate against measurement, compound 4: 2.2-fold (0.33 log units) above, and the stated range covers the measured number.
By their numbers in this assay, from the lowest: compound 1; then compound 4; then compound 2. At a limit, above all of these: compound 3.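

Every earlier step changed the group on the double-bonded chain carbon, which left the amine at the far end of the side chain untested. In this assay putting pyrrolidin-1-yl in place of dimethylamino brings a 2.8-fold lower number from compound 2 to compound 4 (0.45 log units; beyond the scatter) and so shows that this end of the molecule also affects how much compound the cells tolerate, even though the change is modest: a group of 3 heavy atoms gives way to one of 5 that forms a five-membered non-aromatic ring, while the counts of hydrogen-bond donors and acceptors stay the same. Nothing measured here bears on why the number moves, so the reason remains unknown.

As far as these compounds go, it remains open whether the ring itself or simply the extra carbon atoms account for the step, a question that diethylamino, piperidin-1-yl or morpholin-4-yl at the same place could help to answer. From the compounds shown here alone, it is also open whether the same swap would give a similar step with 1,3-benzothiazol-2-yl or 4-(methylsulfonyl)phenyl on the double-bonded chain carbon, as the pyrrolidin-1-yl end appears here only with pyridin-4-yl.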